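A few compounds are considered here, and "the series" means these few. Any claim that something is new, unique, unknown or untested is made for them only; others in the source may bear on it.

Compound 2 `OCCCNc1nc(-c2ccccc2)nc2c1nnn2Cc1ccccc1Cl` and compound 1 `Clc1ccccc1Cn1nnc2c(NC3CCCC3)nc(-c3ccccc3)nc21` share one core and differ only in the group on a nitrogen on an aromatic ring. In an assay on isolated protein for binding affinity to adenosine receptor A1 (Bos taurus) (on this read-out higher numbers stand for weaker inhibition and lower numbers for stronger inhibition), compound 1 gives 9000000 nM, while compound 2 gives 33000000 nM, the higher of the two numbers; the step of a 3.7-fold higher number from compound 1 to compound 2 (0.56 log units; beyond the scatter) lies beyond the scatter. Compound 3 `Clc1ccccc1Cn1nnc2c(NC3CC3)nc(-c3ccccc3)nc21` is not yet measured. It differs from compound 2 by cyclopropyl in place of 3-hydroxypropyl on a nitrogen on an aromatic ring. For the measured compounds named here, the one step on record, from cyclopentyl to 3-hydroxypropyl, raised the number; the change to cyclopropyl again removes the 3-hydroxypropyl chain in favour of a ring of carbon only, so the reverse direction is expected, though the ring is smaller than in compound 1. Compound 3 is therefore expected to give about 12000000 nM, within 5000000 nM to 30000000 nM, a step of a 2.8-fold lower number from compound 2 to compound 3 (0.44 log units; beyond the scatter).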

Compound 3, inhibition constant: 11000000 nM
The estimate for compound 3 lay 1.1-fold (0.04 log units) above the measured number; measured number inside the range.
By their numbers in this assay, from the lowest: compounds 1 and 3 (each within the scatter of the next); then compound 2.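

In this assay, putting cyclopropyl where compound 2 carries 3-hydroxypropyl gives a 3.0-fold lower number from compound 2 to compound 3 (0.48 log units; beyond the scatter) and so a second carbon-only ring, not just cyclopentyl, stands apart from the open chain with its hydroxyl group. Ring size shows no effect across these two rings: cyclopropyl in place of cyclopentyl gives a 1.2-fold higher number from compound 1 to compound 3 (0.09 log units; within the scatter) and that step cannot separate the two compounds. Nothing available explains why the numbers fall this way.

The compounds shown leave open whether the higher number of compound 2 goes with its hydroxyl group or with having an open chain instead of a ring, which a plain propyl chain on the same nitrogen could separate. As far as these compounds go, how a larger ring such as cyclohexyl, or a chain ending in an amine, would read at this position also remains open.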